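Removing the methoxy from an inactive dichlorophenyl analogue

The compounds below may be only part of what the source reports. "The series", "measured", "known", "first", "only" and "open" are said of these compounds alone.

Compound 1 `C=CCn1c(=O)/c(=C\c2ccccc2Cl)[nH]c(=O)/c1=C\c1ccccc1OC` and compound 3 `C=CCn1c(=O)/c(=C\c2ccccc2C(F)(F)F)[nH]c(=O)/c1=C\c1ccccc1OC` both carry a 2-methoxyphenyl arm on the shared core. In a functional assay on MOLT-4 cells (Homo sapiens) for cytotoxicity, read by CCK-8 assay, with a stated time of 72 h (on this read-out higher numbers stand for weaker inhibition and lower numbers for stronger inhibition), compound 1 gives 4400 nM and compound 3 gives 4400 nM, so no change at the digits printed from compound 1 to compound 3 (within the scatter). Compound 2 `C=CCn1c(=O)/c(=C\c2ccc(Cl)c(Cl)c2)[nH]c(=O)/c1=C\c1ccccc1OC` differs from them in its dichlorophenyl arm and stands apart: in this assay compound 2 is reported only as "not active" (no number reported), with no single number. Compound 4 `C=CCn1c(=O)/c(=C\c2ccc(Cl)c(Cl)c2)[nH]c(=O)/c1=C\c1ccccc1` is compound 2 with hydrogen in place of methoxy on an aromatic carbon. For the measured compounds named here, none of the measured steps touches the methoxy, so nothing measured bears directly on this change. Since compound 2 itself gave no number in this assay, compound 4 is expected to remain weak, with an estimated value around 30000 nM and a range from 6000 nM to 150000 nM, most likely reported again only as a limit.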

Compound 4, half-maximal inhibitory concentration: "not active" (no number reported)
For compound 4 the study gives words and no number, so the estimate cannot be set against anything.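

For the compounds shown here, compound 2 and compound 4 are both reported only in words, so no step between them can be read. The compounds shown leave open whether replacing methoxy with hydrogen changes activity at all, and no supporting evidence bears on this result.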